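The source may hold more compounds than are shown below. What is called first, only, known or untested is meant among the compounds shown, and "the series" means these compounds.

Measured to date:
compound 1 `O=C(/C(=C\c1ccc(Cl)cc1Cl)S(=O)(=O)c1ccc(Br)cc1)c1ccc(Br)cc1` — 10000 nM
compound 2 `COc1ccc(/C=C(\C(=O)c2ccc(Cl)cc2)S(=O)(=O)c2ccc(Br)cc2)cc1O` — 10000 nM
compound 3 `COc1ccccc1/C=C(\C(=O)c1ccc(Cl)cc1)S(=O)(=O)c1ccc(Br)cc1` — 10000 nM

In a functional assay on DU-145 cells (Homo sapiens) for inhibition, read by trypan blue exclusion, with a stated time of 96 h (on this read-out higher numbers stand for weaker inhibition of growth and lower numbers for stronger inhibition of growth), compound 3 gives 10000 nM. It stands level with compound 1 and compound 2 at the digits shown; against compound 1 no change within the scatter, against compound 2 likewise no change within the scatter. Going by the values given here, the one step read so far, no change at the digits printed from compound 2 to compound 3 (within the scatter), shows that exchanging the aryl group on the double-bonded chain carbon leaves the read-out where it was.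

Compound 4 `O=C(/C(=C\c1ccc(Cl)cc1Cl)S(=O)(=O)c1ccc(Br)cc1)c1ccc(Cl)cc1` is the next member. Relative to compound 3 the change is 2,4-dichlorophenyl in place of 2-methoxyphenyl on a double-bonded chain carbon bound to a double-bonded chain carbon. The same part of the molecule is varied as in the step from compound 2 to compound 3, which was flat, so that step bears directly on this one. Compound 1 already carries the 2,4-dichlorophenyl group on the double-bonded chain carbon and gives 10000 nM, which is also level with compound 3. Among the compounds with values here, nothing among the measured compounds points to a move beyond the scatter in this assay. The step to compound 4 is therefore expected to be no change at the digits printed from compound 3 to compound 4 (within the scatter). Compound 4 is estimated at 10000 nM, within 5000 nM to 20000 nM.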

Compound 4, concentration for 50% growth inhibition: 50000 nM
Beside the measured number, compound 4's estimate is 5.0-fold (0.70 log units) below it; the whole stated range lies below it.
By their numbers in this assay, from the lowest: compounds 1, 2 and 3 (each within the scatter of the next); then compound 4.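

In this assay the position on the double-bonded chain carbon no longer reads as flat: after no change at the digits printed from compound 2 to compound 3 (within the scatter) come a 5.0-fold higher number from compound 3 to compound 4 (0.70 log units; beyond the scatter) and a 5.0-fold higher number from compound 2 to compound 4 (0.70 log units; beyond the scatter), so 2,4-dichlorophenyl separates from both 2-methoxyphenyl and 3-hydroxy-4-methoxyphenyl, although those two groups do not separate from each other. The 2,4-dichlorophenyl group alone does not fix the read-out, since compound 1 carries it too, and a 5.0-fold higher number from compound 1 to compound 4 (0.70 log units; beyond the scatter) comes with chloro in place of bromo on an aromatic carbon, a halogen exchange outside the position varied in the other two new steps. No measurement at hand accounts for either kind of step.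

Going by these compounds, it remains open whether chloro in place of bromo would give a comparable step with 2-methoxyphenyl or 3-hydroxy-4-methoxyphenyl on the double-bonded chain carbon, so the two changes cannot yet be read apart across the series. On these data alone, it is also open how a dimethylamino group or a carboxylic acid on that aryl group would read, and whether any such group would give a number lower than those of compounds 1, 2 and 3.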